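Phenyl for naphthalenyl on the triazole nitrogen of compound 1

A few compounds are considered here, and "the series" means these few. Any claim that something is new, unique, unknown or untested is made for them only; others in the source may bear on it.

Measured compounds:
compound 1 `O=C1C=CC2(C=C1)OCC(=O)N2c1nc(-c2ccc3ccccc3c2)nn1-c1ccc2ccccc2c1`: 250 nM
compound 2 `CC1OC2(C=CC(=O)C=C2)N(c2nc(-c3ccc4ccccc4c3)nn2-c2ccc3ccccc3c2)C1=O`: 300 nM
compound 3 `CC1CN(c2nc(-c3ccc4ccccc4c3)nn2-c2ccccc2)C2(C=CC(=O)C=C2)O1`: 320 nM

In a functional assay on A549 cells (Homo sapiens) for antiproliferative activity, with a stated time of 5 days (a higher number here means a weaker inhibitor, a lower number a stronger inhibitor), compound 1 gives the lowest of the three numbers, but compound 2 and compound 3 both sit within the scatter of it, so no order among them can be claimed. Compound 4 `O=C1C=CC2(C=C1)OCC(=O)N2c1nc(-c2ccc3ccccc3c2)nn1-c1ccccc1` is not yet measured; it differs from compound 1 by phenyl in place of naphthalen-2-yl on an aromatic nitrogen. Among the measured compounds shown here, no measured step tests this change alone. For the measured compounds named here, the only step on record, a 1.2-fold higher number from compound 1 to compound 2 (0.08 log units; within the scatter), concerns the methyl and is within the scatter. Compound 3, which carries phenyl on that nitrogen but also other changes, gives 320 nM against compound 2 with 300 nM, a difference within the scatter. Compound 4 is therefore expected to show a 1.2-fold higher number from compound 1 to compound 4 (0.08 log units; within the scatter), with an estimated 300 nM in a range of 150 nM to 600 nM.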

Compound 4, half-maximal inhibitory concentration: 140 nM
The estimate for compound 4 lay 2.1-fold (0.33 log units) above the measured number; measured number outside the range, below it.
By their numbers in this assay, from the lowest: compounds 4, 1, 2 and 3 (each within the scatter of the next, the first and the last beyond it).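

Among the compounds shown here, compound 4 tests phenyl in place of naphthalen-2-yl on this aromatic nitrogen as the only change, and in this assay the step is a 1.8-fold lower number from compound 1 to compound 4 (0.25 log units; within the scatter). At this position, one six-membered aromatic ring therefore serves as well as the two of naphthalen-2-yl, within the resolution of this read-out. Nothing at hand bears on the cause of this result.

The compounds shown leave open how a cyclohexyl group, a benzyl group or an aminoethyl chain would behave on this nitrogen. They also leave open whether the remaining naphthalen-2-yl group could be exchanged for phenyl in the same way.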